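A few compounds are considered here, and "the series" means these few. Any claim that something is new, unique, unknown or untested is made for them only; others in the source may bear on it.

Measured compounds in a functional assay on HeLa cells (Homo sapiens) for antiproliferative activity, read by MTT assay, with a stated time of 72 h; on this read-out lower numbers stand for stronger inhibition and higher numbers for weaker inhibition:
- compound 1, `O=C(Nc1ccc(Cl)c(-c2nnc3c(Cl)cccn23)c1)c1cccnc1`: compound 1 gives > 100000 nM, a limit of the assay.
- compound 2, `O=C(Nc1ccc(Cl)c(-c2nnc3c(Cl)cccn23)c1)c1ccc(Cl)cc1`: compound 2 gives > 100000 nM, also a limit.
- compound 3, `O=C(Nc1ccc(Cl)c(-c2nnc3c(Cl)cccn23)c1)c1cccnc1Cl`: compound 3 gives 87500 nM.

Going by the values given here, compound 3 therefore holds the only number in this assay; the other two values are limits, as the limit of > 100000 nM in this assay, at which 2 of the 3 values shown sit, records. Against those limits the steps are only readable as floors: an at least 1.1-fold lower number from compound 1 to compound 3 (0.05 log units; that floor lies within the scatter) and an at least 1.1-fold lower number from compound 2 to compound 3 (0.05 log units; that floor lies within the scatter), both floors lying within the scatter, while a step that the two limits leave unreadable from compound 1 to compound 2.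

Compound 4, `O=C(Nc1ccc(Cl)c(-c2nnc3c(Cl)cccn23)c1)c1ccccc1Cl`, has not been measured. It differs from compound 3 by 2-chlorophenyl in place of 2-chloropyridin-3-yl on a carbonyl carbon. Among the compounds with values here, the step that bears on it most directly is the one from compound 2 to compound 3, where a 4-chlorophenyl on the carbonyl carbon was exchanged for 2-chloropyridin-3-yl and the number fell by an unreadable amount no larger than the floor. Compound 4 reverses the pyridine-to-benzene part of that exchange while keeping the chlorine. Compound 4 is therefore expected to sit near compound 3 or drift back toward the limit, an expected step of a 1.3-fold higher number from compound 3 to compound 4 (0.10 log units; within the scatter) in this assay, not clearly beyond the scatter. The estimated value for compound 4 in this assay is 110000 nM, with a range from 40000 nM to 300000 nM.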

Compound 4, half-maximal inhibitory concentration: > 100000 nM
Compound 4 gave a limit, no number; the forecaster's own chance of this, stated with the estimate: 50%; the middle value does not contradict the limit.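

Compound 4 is the only compound shown with 2-chlorophenyl on the carbonyl carbon, and in this assay it ends at a limit of the assay, so this chlorinated carbon ring gives no number there. Set against compound 1, it also shows that each of the two single changes now available from compound 3 at this acyl group, removing the chloro or replacing the pyridine ring with a carbon-only ring, leads to a limit; the second of these changes reads as an at least 1.1-fold higher number from compound 3 to compound 4 (0.05 log units; that floor lies within the scatter), so no real difference between 2-chloropyridin-3-yl and 2-chlorophenyl is established. That step remains only a floor, and the steps from compound 1 and compound 2 to compound 4 cannot be read, because most of the values rest on one ceiling: the limit of > 100000 nM in this assay, at which 3 of the 4 values shown sit.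

The compounds shown leave open whether any group on the carbonyl carbon can give a value well clear of that limit. They also leave open whether the small separation of compound 3 from the others reflects any real effect of its 2-chloropyridin-3-yl group.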